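The compounds below may be only part of what the source reports. "The series", "measured", "known", "first", "only" and "open" are said of these compounds alone.

Measured so far:
compound 1, `CCOc1cc(C(C)(C)C)ccc1C1=NC(c2ccc(Cl)cc2)C(c2ccc(Cl)cc2)N1C(=O)N1CCN(Cc2ccc(C(=O)NO)cc2)CC1`: 2170 nM
compound 2, `CCOc1cc(C(C)(C)C)ccc1C1=NC(c2ccc(Cl)cc2)C(c2ccc(Cl)cc2)N1C(=O)NCCCCC(=O)Nc1ccccc1N`: 18400 nM

In a functional assay on A549 cells (Homo sapiens) for antiproliferative activity, read by CCK-8 assay, with a stated time of 72 h (on this read-out lower numbers stand for stronger inhibition and higher numbers for weaker inhibition), compound 1 gives 2170 nM, the lowest of the two numbers; compound 2 gives 18400 nM, a higher number beyond the scatter. Within the data shown here, no step between compounds differing in one place is available.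

Compound 3, `CCOc1cc(C(C)(C)C)ccc1C1=NC(c2ccc(Cl)cc2)C(c2ccc(Cl)cc2)N1C(=O)N1CCN(CCCCCCCC(=O)NO)CC1`, differs from compound 1 by 6-(hydroxycarbamoyl)hexyl in place of 4-(hydroxycarbamoyl)phenyl on a saturated chain carbon bound to an amine nitrogen in a ring. Among the measured compounds shown here, with no comparable step to draw on, no shift beyond the scatter is expected in this assay; the estimated step of a 1.4-fold higher number from compound 1 to compound 3 (0.14 log units; within the scatter) is small. Compound 3 is expected at 3000 nM, within 800 nM to 12000 nM.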

Compound 3, half-maximal inhibitory concentration: 2010 nM
Beside the measured number, compound 3's estimate is 1.5-fold (0.17 log units) above it, and the stated range covers the measured number.
By their numbers in this assay, from the lowest: compounds 3 and 1 (each within the scatter of the next); then compound 2.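

In this assay, 6-(hydroxycarbamoyl)hexyl in place of 4-(hydroxycarbamoyl)phenyl gives a 1.1-fold lower number from compound 1 to compound 3 (0.03 log units; within the scatter) and stays within the scatter. At this place, on a saturated chain carbon bound to an amine nitrogen in a ring, an open chain can therefore stand in for the aromatic ring without a shift beyond the scatter. No supporting measurement explains this outcome.

On these data alone, whether a shorter or longer chain ending in hydroxycarbamoyl holds this level remains open. So does the effect of a carboxylic acid in place of that hydroxycarbamoyl end.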